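The compounds below may be only part of what the source reports. "The series", "measured", "known", "first", "only" and "open" are said of these compounds alone.

Measured compounds:
compound 1 `CCc1ccc(C(CCN2CCN(c3ccccc3OC)CC2)Oc2ccc(NC(=O)c3ccccc3OCCCC(=O)O)cc2)cc1` with 200 nM
compound 2 `COc1ccccc1N1CCN(CCC(Oc2ccc(NC(=O)c3ccccc3OCCCC(=O)O)cc2)c2ccc(CC(C)C)cc2)CC1` with 6310 nM
compound 3 `CCc1ccc(C(CCN2CCN(c3ccccc3OC)CC2)Oc2ccc(C(=O)Nc3ccccc3OCCCC(=O)O)cc2)cc1` with 39.8 nM

In an assay on Prostate gland (Oryctolagus cuniculus) for inhibition of Adrenergic receptor alpha-1 (Homo sapiens) (on this read-out higher numbers stand for weaker binding and lower numbers for tighter binding), compound 1 gives 200 nM, compound 2 gives 6310 nM and compound 3 gives 39.8 nM. Compound 3 stands lowest of the three, and its steps to compound 1 and compound 2 both lie beyond the usual scatter. Compound 1 and compound 2 share one core and differ in a single place: isopropyl in place of methyl on a saturated chain carbon bound to an aromatic carbon That change produced a 32-fold higher number from compound 1 to compound 2 (1.50 log units; beyond the scatter), a large weakening of binding. Compound 1 and compound 3 have the same atoms joined differently; the difference between the two cores is not broken down here.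

Compound 4 `COc1ccccc1N1CCN(CCC(Oc2ccc(C(=O)Nc3ccccc3OCCCC(=O)O)cc2)c2ccc(CC(C)C)cc2)CC1` has not yet been measured. It differs from compound 3 in exactly one place: isopropyl in place of methyl on a saturated chain carbon bound to an aromatic carbon This is the same change that was made from compound 1 to compound 2, at the same kind of place, so the step from compound 3 to compound 4 is expected to be of similar size, estimated at a 25-fold higher number from compound 3 to compound 4 (1.40 log units; beyond the scatter), because compound 2 showed a 32-fold higher number from compound 1 to compound 2 (1.50 log units; beyond the scatter). On that basis compound 4 is expected to give 1000 nM in this assay, with a likely range from 250 nM to 4000 nM.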

Compound 4, dissociation constant: 2000 nM
The estimate for compound 4 lay 2.0-fold (0.30 log units) below the measured number; measured number inside the range.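

In this assay, swapping 4-ethylphenyl for 4-isobutylphenyl gives a 50-fold higher number from compound 3 to compound 4 (1.70 log units; beyond the scatter), a large weakening of binding. Set beside the earlier case, the change carries over from one core to the other with much the same size: the same change on two cores in this assay, a 32-fold higher number (1.50 log units; beyond the scatter) from compound 1 to compound 2 and a 50-fold higher number (1.70 log units; beyond the scatter) from compound 3 to compound 4, 1.6-fold (0.20 log units) apart, within the scatter of two such steps. Among these compounds, this is only two pairs of compounds on two cores with the same atoms joined differently, so it does not show that the step would keep its size on any other core, and it does not explain why binding weakens.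

The compounds shown carry only ethyl or isobutyl in this place, so it remains open whether a propyl chain, a longer chain or a cyclopropyl ring would give a smaller, similar or larger step. As far as these compounds go, it is also open whether the step would keep its size if an amine replaced the carboxylic acid at the end of the other chain.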